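This account rests on a few compounds, and the source may have more. Where it says the series, first, only, none or still open, it means among the compounds named here.

Measured compounds:
- Compound 1, `CCn1cc(-c2nc3ccccc3o2)c(=O)c2cc(F)c(N3CCN(C)CC3)cc21`: 700 nM
- Compound 2, `CCn1cc(-c2nc3ccccc3s2)c(=O)c2cc(F)c(N3CCNC(C)C3)c(F)c21`: 9800 nM
- Compound 3, `CCn1cc(-c2nc3ccc([N+](=O)[O-])cc3o2)c(=O)c2cc(F)c(N3CCN(C)CC3)cc21`: 39600 nM

All three were tested in a functional assay on A2780 cells (Homo sapiens) for cytotoxicity, read by MTT assay, with a stated time of 48 h; on this read-out higher numbers stand for weaker inhibition and lower numbers for stronger inhibition. Compound 1 gives the lowest number of the three, and compound 3 differs from it only by nitro in place of hydrogen on an aromatic carbon; that single change brought a 57-fold higher number from compound 1 to compound 3 (1.75 log units; beyond the scatter), a clear weakening well outside the usual scatter. Compound 2 stands between them, with a number that sits clearly above compound 1 and clearly below compound 3.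

Compound 4, `CCn1cc(-c2nc3ccc([N+](=O)[O-])cc3s2)c(=O)c2cc(F)c(N3CCNC(C)C3)c(F)c21`, has not yet been measured. It is related to compound 2 by nitro in place of hydrogen on an aromatic carbon, the same change as that from compound 1 to compound 3, made at the same kind of place on the ring. The difference between the core of compound 2 and the core of compound 1 is not broken down here.

For compound 4 in this assay, a weakening is expected, because in compound 1 the same change produced a 57-fold higher number from compound 1 to compound 3 (1.75 log units; beyond the scatter). The expected step is a 5.1-fold higher number from compound 2 to compound 4 (0.71 log units; beyond the scatter), judged somewhat smaller than the earlier one because compound 2 already starts at 9800 nM. The estimate for compound 4 is therefore 50000 nM, expected to fall between 12000 nM and 250000 nM.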

Compound 4, half-maximal inhibitory concentration: 3300 nM
Compound 4: the middle estimate sits 15-fold (1.18 log units) above what was measured; measured number outside the range, below it.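

In this assay, nitro in place of hydrogen on an aromatic carbon gave a 3.0-fold lower number from compound 2 to compound 4 (0.47 log units; beyond the scatter), so on this core the change brought stronger inhibition, not the weakening seen on the core of compound 1. Set side by side, the two steps show that this change does not carry over from one core to the other in this series, not even in its direction: the same change on two cores in this assay, a 57-fold higher number (1.75 log units; beyond the scatter) from compound 1 to compound 3 and a 3.0-fold lower number (0.47 log units; beyond the scatter) from compound 2 to compound 4, 170-fold (2.23 log units) apart, beyond the scatter of two such steps. Within the data shown here, compound 1 and compound 2 differ in more than one place, and with only one pair on each core, the result does not show which of those differences turns the step around, nor how the change would behave on any further core.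

The compounds shown leave open whether any single difference between the two cores would be enough to reverse the step, a question that needs pairs of compounds differing in one place only. They also leave open how an amine or a carboxylic acid on the same aromatic carbon would compare with hydrogen and nitro on each of the two cores.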